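Swapping the Aryl Group on an Aromatic Nitrogen

The source may report more compounds than this note shows. Statements on the series, on what has been measured and on what is new or still open speak of the compounds shown alone.

Compound 1 `N#CC1=C(N)Oc2c(c3nc4ccccc4nc3c3ccccc23)C12C(=O)N(Cc1cnnn1-c1cccc(S(N)(=O)=O)c1)c1ccccc12` and compound 2 `COc1ccccc1-n1nncc1CN1C(=O)C2(C(C#N)=C(N)Oc3c(N)cc4nc5ccccc5nc4c32)c2ccccc21` share one core. In a functional assay on A549 cells (Homo sapiens) for antiproliferative activity, read by MTT assay, with a stated time of 48 h (on this read-out higher numbers stand for weaker inhibition and lower numbers for stronger inhibition), compound 1 gives 44200 nM, and compound 2 gives 37500 nM; the two numbers lie within the scatter of each other, so compound 2 sits level with compound 1 rather than apart from it. Going by the values given here, compound 3 `N#CC1=C(N)Oc2c(N)cc3nc4ccccc4nc3c2C12C(=O)N(Cc1cnnn1-c1ccc(F)c(Cl)c1)c1ccccc12` keeps that core and changes only one group: 3-chloro-4-fluorophenyl in place of 2-methoxyphenyl on an aromatic nitrogen. Among the compounds with values here, no measured pair shows what such a change does here, so the expected step of a 1.2-fold lower number from compound 2 to compound 3 (0.07 log units; within the scatter) is small, with no direction beyond the scatter. Compound 3 is therefore estimated at 32000 nM in this assay, between 10000 nM and 90000 nM.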

Compound 3, half-maximal inhibitory concentration: 43400 nM
For compound 3 the middle estimate is 1.4-fold (0.13 log units) below the measured one; measured number inside the range.
By their numbers in this assay, from the lowest: compounds 2, 3 and 1 (each within the scatter of the next).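

In this assay, going by these compounds alone, this is the first pair that differs only in the aryl group on the aromatic nitrogen, and it gives a 1.2-fold higher number from compound 2 to compound 3 (0.06 log units; within the scatter). Within the data shown here, at this position, 3-chloro-4-fluorophenyl and 2-methoxyphenyl therefore cannot be told apart, although the hydrogen-bond acceptor of the leaving group has no counterpart in the entering one. Nothing available explains this result. The compounds shown leave open whether the position would respond to something other than a substituted phenyl ring, such as a simple alkyl chain, or to an amine or carboxylic acid on that ring.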